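The compounds below may be only part of what the source reports. "The series", "measured", "known", "first", "only" and "open" are said of these compounds alone.

Measured compounds:
Compound 1 `O=C(O)/C=C/C(=O)Nc1cccc(-c2nc3ccccc3s2)c1`: in an ADME assay on HEK293 cells (Homo sapiens) for inhibition, with a stated time of 72 h (on this read-out higher numbers stand for an effect only at larger amounts of compound and lower numbers for an effect already at smaller amounts), compound 1 gives > 25000 nM, a limit of the assay.
Compound 2 `CN(C)CCC(=O)Nc1cccc(-c2nc3ccccc3s2)c1`: in this assay compound 2 gives > 25000 nM, again a limit.
Compound 3 `CC(C)(CCl)C(=O)Nc1cccc(-c2nc3ccccc3s2)c1`: in this assay compound 3 gives > 25000 nM, also a limit.

Compound 3 thus stands at the limit, as do the other two; all three values sit at the limit of > 25000 nM in this assay, at which 3 of the 3 values shown sit. The steps a step that the two limits leave unreadable from compound 1 to compound 2, a step that the two limits leave unreadable from compound 1 to compound 3 and a step that the two limits leave unreadable from compound 2 to compound 3 are unreadable in size, since each is bounded by limits on both sides. Nothing in the shared core has yet given a number.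

The next change is 3-chloropyridin-4-yl in place of 1-(chloromethyl)-1-methylethyl on a carbonyl carbon, giving compound 4 `O=C(Nc1cccc(-c2nc3ccccc3s2)c1)c1ccncc1Cl`. The measured steps bearing on it, the replacement of one group on the carbonyl carbon by another, are all unreadable, so they give no direction for this assay. Going by the values given here, with every value so far at the limit, the expectation for compound 4 is that it stays at or near the limit, with a step that the limit leaves unreadable from compound 3 to compound 4 expected to be small in either direction. Compound 4 is estimated at 30000 nM, with a range from 8000 nM to 100000 nM, and most likely the assay reports only a limit.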

Compound 4, half-maximal effective concentration: > 25000 nM
Compound 4: only a limit was reported; the forecaster's own chance of this, stated with the estimate: 80%; the middle value lies beyond the limit too.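

In this assay compound 4 gives > 25000 nM, a limit and not a number. The steps to compound 4 from compound 1, compound 2 and compound 3 cannot be read, as all four results are limits: the limit of > 25000 nM in this assay, at which 4 of the 4 values shown sit.

The compounds shown leave open whether any group on the carbonyl carbon gives a measurable value in this assay.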